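Side-chain exchange from compound 1 to compound 4

This account rests on a few compounds, and the source may have more. Where it says the series, first, only, none or still open, it means among the compounds named here.

In a functional assay on MCF7 cells (Homo sapiens) for antiproliferative activity, read by MTT assay, with a stated time of 24 h (on this read-out higher numbers stand for weaker inhibition and lower numbers for stronger inhibition), compound 1 (`CCCC(O)(C#Cc1ccc(C(CC)(CC)C2=CN(CC)C(C(=O)NCCN(CC)CC)C2)cc1C)CCC`) gives 1290 nM, the second highest of three numbers. Compound 2 (`CCN(CC)CCNC(=O)C1CC=C(C(CC)(CC)c2ccc(C#CC(C)(C)O)c(C)c2)N1CC`) gives 1490 nM, within the scatter of compound 1. Compound 3 (`CCN(CC)CCNC(=O)C1CC=C(C(CC)(CC)c2ccc(C#CC(C)(O)CC)c(C)c2)N1CC`) gives 600 nM, lower than compound 1 beyond the scatter. Compound 4 (`CCN(CC)CCNC(=O)C1CC(C(CC)(CC)c2ccc(CCC(O)(CC)CC)c(C)c2)=CN1CC`) differs from compound 1 on an aromatic carbon, ortho to a methyl group and para to a large group: a group of 8 heavy atoms (7 carbon, 1 oxygen; no ring) in place of a group of 10 heavy atoms (9 carbon, 1 oxygen; no ring), on an aromatic carbon. Within the data shown here, the only measured step that bears on this is modest, a 2.5-fold lower number from compound 2 to compound 3 (0.40 log units; beyond the scatter), and it adds a methyl on a core that differs from that of compound 1. Among the measured compounds shown here, no measured step covers loss of the triple bond. In this assay no change beyond the scatter is expected, with the estimated step being a 1.1-fold lower number from compound 1 to compound 4 (0.03 log units; within the scatter). For compound 4 the estimated value is 1200 nM, with an expected range of 450 nM to 3200 nM.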

Compound 4, half-maximal inhibitory concentration: 3580 nM
Compound 4: the middle estimate sits 3.0-fold (0.47 log units) below what was measured, and the stated range ends below it.
By their numbers in this assay, from the lowest: compound 3; then compounds 1 and 2 (each within the scatter of the next); then compound 4.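

In this assay, a step of a 2.8-fold higher number from compound 1 to compound 4 (0.44 log units; beyond the scatter) follows when 3-ethyl-3-hydroxypentyl replaces the group with the triple bond on the aromatic carbon para to a large group, so this position responds to its side chain on the core of compound 1. The change removes the triple bond and lowers the heavy-atom count together, and the step cannot separate the two. No evidence at hand accounts for the step.

Open, as far as these compounds go, is whether the triple bond or the chain size carries the difference. Also open, from the compounds shown here alone, is how an amine in place of the hydroxyl on this chain would read.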